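A few compounds are considered here, and "the series" means these few. Any claim that something is new, unique, unknown or untested is made for them only; others in the source may bear on it.

Compound 2 `COC(=O)CCCCCCCCCCCCCC/C=C1\CC(CO)(COC(=O)C(C)(C)C)OC1=O` gives 3.86 ug/mL in a functional assay on COLO 205 cells (Homo sapiens) for antiproliferative activity (a lower number here means a stronger inhibitor of growth, a higher number a weaker inhibitor of growth), the highest of the two numbers measured here. Its nearest neighbour is compound 1 `COCCCCCCCCCCCCCCC/C=C1\CC(CO)(COC(=O)C(C)(C)C)OC1=O`, which gives 0.118 ug/mL; the two differ only by methoxycarbonyl in place of methoxymethyl, and the step of a 33-fold higher number from compound 1 to compound 2 (1.51 log units; beyond the scatter) is large and beyond the scatter. Compound 3 `CCCCCOCCCCCCC/C=C1\CC(CO)(COC(=O)C(C)(C)C)OC1=O` is not yet measured. It differs from compound 2 by pentyloxy in place of 7-(methoxycarbonyl)heptyl on a saturated chain carbon, seven bonds along the chain from a double-bonded chain carbon. For the measured compounds named here, the methoxycarbonyl group, whose arrival in compound 2 coincided with the large step of a 33-fold higher number from compound 1 to compound 2 (1.51 log units; beyond the scatter), is gone in compound 3, so the number is expected to move back toward that of compound 1; however, no measured step reports what removing part of the chain does, so the size of the return is uncertain. For compound 3 the expected step is a 9.7-fold lower number from compound 2 to compound 3 (0.98 log units; beyond the scatter), giving an estimate of 0.4 ug/mL in this assay, within a range from 0.08 ug/mL to 2 ug/mL.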

Compound 3, concentration for 50% growth inhibition: 0.491 ug/mL
Estimate against measurement, compound 3: 1.2-fold (0.09 log units) below; low and high end bracket the measured number.
By their numbers in this assay, from the lowest: compound 1; then compound 3; then compound 2.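

In this assay, replacing 7-(methoxycarbonyl)heptyl with pentyloxy gives a 7.9-fold lower number from compound 2 to compound 3 (0.90 log units; beyond the scatter), so a compound without the methoxycarbonyl group recovers much of the ground that compound 2 lost. The recovery is only partial: pentyloxy in place of 8-methoxyoctyl gives a 4.2-fold higher number from compound 1 to compound 3 (0.62 log units; beyond the scatter), so having an ether oxygen in the chain does not by itself bring back the number of compound 1. Nothing available here accounts for either step.

Compound 1 and compound 3 differ in both the length of the chain and where its oxygen lies, and the two effects cannot be separated. On these data alone, how a carboxylic acid, an amine or a longer ether chain in place of pentyloxy would behave at this position also remains open.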